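Cytotoxicity of a Bromonaphthyridine Carboxamide Series on Colon Carcinoma Cells

A few compounds are considered here, and "the series" means these few. Any claim that something is new, unique, unknown or untested is made for them only; others in the source may bear on it.

The account concerns three compounds sharing one core, differing only in the group carried on an amide-type nitrogen. Compound 1 `N[C@H]1CC[C@H](Nc2c(C(=O)NCc3ccco3)nc(Br)c3cccnc23)CC1` bears a (furan-2-yl)methyl group there; compound 2 `N[C@H]1CC[C@H](Nc2c(C(=O)NCc3cccs3)nc(Br)c3cccnc23)CC1` bears a (thiophen-2-yl)methyl group. In a functional assay on HCT-116 cells (Homo sapiens) for cytotoxicity, read by MTT assay, with a stated time of 72 h (on this read-out lower numbers stand for stronger inhibition and higher numbers for weaker inhibition), compound 1 gives only a limit, > 10000 nM, and not a number. For compound 2 this assay records "not determined" (no result reported), so no single number places it. Of the two values shown for this pair, one sits at the limit of > 10000 nM in this assay, at which 1 of the 2 values shown sits, and the other is absent, so compound 2 stands on no measured ground at all.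

Compound 3 `C[C@H](NC(=O)c1nc(Br)c2cccnc2c1N[C@H]1CC[C@H](N)CC1)c1ccc(F)cc1` is to be measured in this assay. The change from compound 2 to compound 3 is 1-(4-fluorophenyl)ethyl in place of (thiophen-2-yl)methyl on an amide-type nitrogen. Going by the values given here, no step between measured compounds is available to scale this change, and the one recorded neighbour, compound 1, gives a limit rather than a number, so the expectation for compound 3 is of weak inhibition, with a step of uncertain direction beyond the scatter. Compound 3 is accordingly expected to give about 8000 nM, within a range from 1500 nM to 30000 nM.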

Compound 3, half-maximal inhibitory concentration: > 10000 nM
Compound 3 gave a limit, no number; the forecaster's own chance of this, stated with the estimate: 55%; middle value at least 1.2-fold (0.09 log units) away from the limit.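

In this assay, compound 1 and compound 3 each give only a limit and compound 2 has no result, so no step can be read among them: the limit of > 10000 nM in this assay, at which 2 of the 3 values shown sit.

The compounds shown leave open how far any of the three lies past that limit, and whether the change of group on the amide-type nitrogen alters cytotoxicity at all.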